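Replacing an Octyl Chain with a Hydroxymethyl Group

A few compounds are considered here, and "the series" means these few. Any claim that something is new, unique, unknown or untested is made for them only; others in the source may bear on it.

Compound 3 `CCCCCCCCc1cn(C(c2ccccc2)c2cc3cc(Br)ccc3nc2OC)nn1` gives the highest of the three numbers in an ADME assay on HEK293 cells (Homo sapiens) for cytotoxicity, read by sulforhodamine B assay, with a stated time of 48 h, tested at 10 uM (a lower number here means less inhibition, a higher number more inhibition at the concentration tested (going by the name of the read-out)), with 14.6%. Its nearest neighbour is compound 1 `COc1nc2ccc(Br)cc2cc1C(c1ccccc1)n1cc(C2CC2)nn1` with 8.22%, a gap within the scatter; compound 2 `CCCCc1cn(C(c2ccccc2)c2cc3cc(Br)ccc3nc2OC)nn1` with -3.47% lies furthest away, a number 18.1 percentage points higher from compound 2 to compound 3 (beyond the scatter).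

Compound 4 `COc1nc2ccc(Br)cc2cc1C(c1ccccc1)n1cc(CO)nn1` differs from compound 3 by hydroxy in place of heptyl on a saturated chain carbon bound to an aromatic carbon. The measured steps of a number 11.7 percentage points lower from compound 1 to compound 2 (beyond the scatter) and a number 6.4 percentage points higher from compound 1 to compound 3 (within the scatter) all exchange one chain or ring for another on an aromatic carbon; none introduces a hydroxy group, so they bear only loosely on this change. All three values are low, and the exchanges moved them modestly at most. Compound 4 is therefore expected to stay near the low end, with a step of a number 11.6 percentage points lower from compound 3 to compound 4 (beyond the scatter). The estimate for compound 4 is 3%, ranging from -10% to 16%.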

Compound 4, a percentage reported as inhibition, at one concentration (the size of the read-out at that concentration, not a potency): 11.5%
For compound 4 the middle estimate is 8.5 percentage points below the measured one, within the range that was stated.
By their numbers in this assay, from the lowest: compound 2; then compounds 1, 4 and 3 (each within the scatter of the next).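

In this assay the hydroxymethyl group, the only one shown with a hydrogen-bond donor, sits level with the octyl chain, with a number 3.1 percentage points lower from compound 3 to compound 4 (within the scatter), and with the cyclopropyl group, with a number 3.3 percentage points higher from compound 1 to compound 4 (within the scatter). Only the butyl compound stands apart, with a number 15 percentage points higher from compound 2 to compound 4 (beyond the scatter), so group size does not order these numbers: hydroxymethyl and octyl sit together while butyl lies lower. Nothing available explains this. From the compounds shown here alone, whether an amine or a carboxylic acid at this place would keep the number equally low remains open, as does where a longer chain would fall.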